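Swapping the Sulfonyl Aryl Group: Dimethoxy to Chloro-Trifluoromethyl

The compounds below may be only part of what the source reports. "The series", "measured", "known", "first", "only" and "open" are said of these compounds alone.

Measured compounds:
- Compound 1 `COc1cccc(S(=O)(=O)NCCCNc2ncc(C(=O)c3ccccc3C)s2)c1` gives 11 nM in an assay on isolated protein for inhibition of Neuropeptide Y receptor type 5 (Mus musculus); a higher number here means a weaker inhibitor, a lower number a stronger inhibitor
- Compound 2 `COc1ccc(OC)c(S(=O)(=O)NCCCNc2ncc(C(=O)c3ccccc3C)s2)c1` gives 1.6 nM in this assay

Compound 2 holds the lower of the two numbers in this assay, and its nearest neighbour is compound 1, from which it differs by a single methoxy on an aromatic carbon; that step, a 6.9-fold lower number from compound 1 to compound 2 (0.84 log units; beyond the scatter), lies beyond the scatter.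

Compound 3 `Cc1ccccc1C(=O)c1cnc(NCCCNS(=O)(=O)c2cc(C(F)(F)F)ccc2Cl)s1` has not yet been measured. It differs from compound 2 by 2-chloro-5-(trifluoromethyl)phenyl in place of 2,5-dimethoxyphenyl on a sulfonyl sulfur. Within the data shown here, the only measured step touches this same aryl ring: a 6.9-fold lower number from compound 1 to compound 2 (0.84 log units; beyond the scatter) shows that a methoxy there is worth a modest gain. Compound 3 gives up both methoxy groups and brings in chloro and trifluoromethyl, for which no comparison exists among the measured compounds. Since the loss of one methoxy alone cost a 6.9-fold lower number from compound 1 to compound 2 (0.84 log units; beyond the scatter) in reverse, compound 3 is expected to give a higher number than compound 2, with wide uncertainty from the unknown new substituents. Compound 3 is therefore estimated at 8 nM (range 1.5 nM to 45 nM), which would be a step of a 5.0-fold higher number from compound 2 to compound 3 (0.70 log units; beyond the scatter).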

Compound 3, half-maximal inhibitory concentration: 0.85 nM
Estimate against measurement, compound 3: 9.4-fold (0.97 log units) above; measured number below the stated range.
By their numbers in this assay, from the lowest: compounds 3 and 2 (each within the scatter of the next); then compound 1.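

In this assay, the change to 2-chloro-5-(trifluoromethyl)phenyl on the sulfonyl sulfur gives a 1.9-fold lower number from compound 2 to compound 3 (0.27 log units; within the scatter), so at this position a low number does not depend on the methoxy groups, which compound 3 lacks altogether. Against the 3-methoxyphenyl group, the same ring gives a 13-fold lower number from compound 1 to compound 3 (1.11 log units; beyond the scatter), which, set beside a 6.9-fold lower number from compound 1 to compound 2 (0.84 log units; beyond the scatter), shows that two quite different pairs of substituents on this ring both go with a number beyond the scatter of that of compound 1. Nothing available explains why these two different groups sit within the scatter of each other.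

The compounds shown leave open whether the chloro or the trifluoromethyl accounts for the low number of compound 3, since no ring carrying only one of them appears, and whether the arrangement of substituents on the ring matters on its own. They also leave open how this position would respond to a dimethylamino group or a carboxylic acid on the ring, or to a pyridine in place of the phenyl.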